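Geranyl ether versus free hydroxy on a flavonoid core

The source may report more compounds than this note shows. Statements on the series, on what has been measured and on what is new or still open speak of the compounds shown alone.

The three measured compounds and their values in a functional assay on A549 cells (Homo sapiens) for cytotoxicity, read by XTT assay, with a stated time of 72 h; on this read-out higher numbers stand for weaker inhibition and lower numbers for stronger inhibition:

Compound 1 `CC(C)=CCC/C=C(\C)Cc1c(O)cc(O)c2c(=O)cc(-c3ccccc3)oc12`: 28000 nM
Compound 2 `CC(C)=CCC/C=C(\C)Cc1c(O)cc(O)c2c(=O)c(OC/C=C(\C)CCC=C(C)C)c(-c3ccc(O)cc3)oc12`: 26000 nM
Compound 3 `CC(C)=CCC/C=C(\C)Cc1c(OC/C=C(\C)CCC=C(C)C)cc(O)c2c(=O)cc(-c3ccccc3)oc12`: in compound 3 the value is a limit of the assay, > 100000 nM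

All three share a flavone core carrying a 3,7-dimethylocta-2,6-dien-1-yl chain on a ring carbon. Compound 3 and compound 1 differ by hydrogen in place of 3,7-dimethylocta-2,6-dien-1-yl on an oxygen on an aromatic ring; this step gives an at least 3.5-fold lower number from compound 3 to compound 1 (0.55 log units; beyond the scatter), and the starting value of compound 3 is the limit of > 100000 nM in this assay, at which 1 of the 3 values shown sits. Compound 2 and compound 1 stand within the scatter of each other, so nothing can be said of an order between them. The difference between the core of compound 2 and the core of compound 3 is not broken down here.

Compound 4 `CC(C)=CCC/C=C(\C)Cc1c(O)cc(O)c2c(=O)c(O)c(-c3ccc(O)cc3)oc12` has not yet been measured. It differs from compound 2 by hydrogen in place of 3,7-dimethylocta-2,6-dien-1-yl on an oxygen on an aromatic ring, the same change that leads from compound 3 to compound 1, at a place described in the same words. Going by the values given here, since the one measured example of this change gave an at least 3.5-fold lower number from compound 3 to compound 1 (0.55 log units; beyond the scatter), a lower number is expected again, and the step is estimated at a 2.2-fold lower number from compound 2 to compound 4 (0.34 log units; beyond the scatter). The expectation rests on a single measured step whose starting value is a limit, so the size is uncertain. Compound 4 is therefore expected to give about 12000 nM in this assay, most likely between 4000 nM and 40000 nM.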

Compound 4, half-maximal inhibitory concentration: 26000 nM
For compound 4 the middle estimate is 2.2-fold (0.34 log units) below the measured one, and the stated range covers the measured number.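

In this assay, replacing the 3,7-dimethylocta-2,6-dien-1-yl group on the aromatic oxygen with hydrogen gives no change at the digits printed from compound 2 to compound 4 (within the scatter), so the earlier result does not carry over from one core to the other in this series: the same change on two cores in this assay, an at least 3.5-fold lower number (0.55 log units; beyond the scatter) from compound 3 to compound 1 and no change at the digits printed (within the scatter) from compound 2 to compound 4, at least 3.5-fold (0.55 log units) apart, beyond the scatter of two such steps This does not show how large the earlier step really is, since it starts from a value that is not a number: the limit of > 100000 nM in this assay, at which 1 of the 4 values shown sits. The two pairs also differ both in the core and in which oxygen carries the chain, and two steps alone cannot separate these, so the result does not say which feature of the core of compound 2 goes with the missing step.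

The compounds shown leave open whether a shorter group on the same oxygen, such as a methyl ether or an acetyl ester, would behave like the 3,7-dimethylocta-2,6-dien-1-yl ether on either core. They also leave open what happens when the chain on the ring carbon, which all four compounds keep, is replaced by a smaller group such as methyl or by a carboxylic acid.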